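A few compounds are considered here, and "the series" means these few. Any claim that something is new, unique, unknown or untested is made for them only; others in the source may bear on it.

Working notes on the series, read in a functional assay on A-431 cells (Homo sapiens) for antiproliferative activity, read by CCK-8 assay, with a stated time of 72 h; on this read-out lower numbers stand for stronger inhibition and higher numbers for weaker inhibition. Within the data shown here, compound 1 (`Cc1cc(Nc2cc(N3CCN(C)CC3)nc(Nc3ccc(S(N)(=O)=O)cc3)n2)n[nH]1`) gives 2760 nM, and compound 2 (`Cc1cc(Nc2cc(N3CCN(C)CC3)nc(Nc3cccc(Cl)c3)n2)n[nH]1`) gives 87.5 nM, the lower of the two numbers so far. Compound 3 (`COc1ccc(Nc2nc(Nc3cc(C)[nH]n3)cc(N3CCN(C)CC3)n2)cc1`) has 4-methoxyphenyl in place of 3-chlorophenyl on a nitrogen on an aromatic ring. Among the measured compounds shown here, the only measured step at this place, a 32-fold lower number from compound 1 to compound 2 (1.50 log units; beyond the scatter), is large and beyond the scatter, and it replaces 4-sulfamoylphenyl with 3-chlorophenyl. The expected change is a 3.4-fold higher number from compound 2 to compound 3 (0.54 log units; beyond the scatter), a moderate move toward a higher number, smaller than that measured step. For compound 3 the estimate is 300 nM, with an expected range of 90 nM to 1000 nM.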

Compound 3, half-maximal inhibitory concentration: 385 nM
For compound 3 the middle estimate is 1.3-fold (0.11 log units) below the measured one; the range from low to high includes it.
By their numbers in this assay, from the lowest: compound 2; then compound 3; then compound 1.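

In this assay, the substituted phenyl on this nitrogen sets the level in steps beyond the scatter: 4-methoxyphenyl gives a 4.4-fold higher number from compound 2 to compound 3 (0.64 log units; beyond the scatter), while methoxy in place of sulfamoyl gives a 7.2-fold lower number from compound 1 to compound 3 (0.86 log units; beyond the scatter). Compound 3 therefore lies between the two earlier compounds, so the loss seen with 4-sulfamoylphenyl is not shared by every 4-substituted phenyl shown. Nothing available explains either step.

The step from compound 2 to compound 3 changes both the group and its ring place, which 4-chlorophenyl or 3-methoxyphenyl would separate. On these data alone, how an amine or a carboxylic acid on the phenyl would read remains open.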